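The source may report more compounds than this note shows. Statements on the series, on what has been measured and on what is new or still open speak of the compounds shown alone.

Measured so far:
- compound 1 `O=C1c2ccc(O)cc2O[C@@H](c2cccc(O)c2O)[C@@H]1O`: > 100000 nM
- compound 2 `O=C1c2ccc(O)c(O)c2O[C@H](c2cccc(O)c2O)[C@H]1O`: 17000 nM
- compound 3 `O=C1c2ccccc2O[C@H](c2cccc(O)c2O)[C@H]1O`: > 100000 nM

All three were tested in a functional assay on RAW264.7 cells (Rattus norvegicus) for inhibition, with RAW264.7 (Mus musculus) as the target, read by Griess assay, with stated times of 2 h and 16 h; on this read-out higher numbers stand for weaker inhibition and lower numbers for stronger inhibition. Compound 3 `O=C1c2ccccc2O[C@H](c2cccc(O)c2O)[C@H]1O` reaches only the limit of that assay, > 100000 nM, so no number is known for it, only that it sits at the weak end. Compound 1 `O=C1c2ccc(O)cc2O[C@@H](c2cccc(O)c2O)[C@@H]1O` also gives only a limit, > 100000 nM. For the measured compounds named here, compound 2 `O=C1c2ccc(O)c(O)c2O[C@H](c2cccc(O)c2O)[C@H]1O` is the one compound with a real number, 17000 nM. Two of the three values thus sit at the limit of > 100000 nM in this assay, at which 2 of the 3 values shown sit.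

Compound 4 `O=C1c2ccc(O)cc2O[C@H](c2cccc(O)c2O)[C@H]1O` differs from compound 3 in one place: hydroxy in place of hydrogen on an aromatic carbon. Compound 1 carries the same hydroxy in the same place as compound 4 and still gives only a limit, which gives little reason to expect the hydroxy by itself to move the number far. With compound 3 at a limit, the step from compound 3 to compound 4 cannot be measured from the data shown; the expected step of an at least 1.1-fold lower number from compound 3 to compound 4 (0.04 log units; that floor lies within the scatter) is therefore none beyond the scatter, with a slight lean towards stronger inhibition. Compound 4 is thus estimated at 90000 nM in this assay, within a range from 25000 nM to 300000 nM, and the assay may well report only a limit again.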

Compound 4, half-maximal inhibitory concentration: 70700 nM
For compound 4 the middle estimate is 1.3-fold (0.10 log units) above the measured one; the range from low to high includes it.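

In this assay, adding hydroxy in place of hydrogen on the aromatic carbon that is meta to a fused ring and para to a fused ring gives an at least 1.4-fold lower number from compound 3 to compound 4 (0.15 log units; that floor lies within the scatter), so this change alone cannot be told apart from no change at all. For the compounds shown here, replacing a hydroxy on an aromatic carbon with hydrogen gives a 4.2-fold higher number from compound 2 to compound 4 (0.62 log units; beyond the scatter), the only step here that is clearly beyond the scatter, and it shows that a single hydroxy on this core can shift the number, with stronger inhibition where the hydroxy is present. Inverting all the stereocentres gives an at least 1.4-fold lower number from compound 1 to compound 4 (0.15 log units; that floor lies within the scatter), again only a floor within the scatter, though any real gap in this pair could come from one source alone: the fact that compounds 1 and 4 differ only in the configuration as drawn.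

The true positions of the weakest compounds stay hidden, which keeps two of the steps from being sized exactly: the limit of > 100000 nM in this assay, at which 2 of the 4 values shown sit. The compounds shown also leave open how a methoxy group, an amine or a carboxylic acid would read on that same aromatic carbon, and whether any of them would do better than hydroxy.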